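A cinnamate ester tail changed from methyl to methoxy

This account rests on a few compounds, and the source may have more. Where it says the series, first, only, none or still open, it means among the compounds named here.

Two esters of the shared core have been measured in an assay on PMNL cells for inhibition of Polyunsaturated fatty acid 5-lipoxygenase (Homo sapiens), read by HPLC, with stated times of 5 min and 15 min; on this read-out higher numbers stand for weaker inhibition and lower numbers for stronger inhibition. Compound 1 `COc1cc(/C=C/C(=O)OCCc2cccc(C(F)(F)F)c2)cc(OC)c1O` gives 200 nM. Compound 2 `COc1cc(/C=C/C(=O)OCCc2ccccc2C)cc(OC)c1O` gives 240 nM; of the two numbers it stands at the high end, yet compound 1 lies within the scatter of it, so no order between the two can be claimed. Compound 3 `COc1cccc(CCOC(=O)/C=C/c2cc(OC)c(O)c(OC)c2)c1` has not yet been measured in this assay. It differs from compound 2 in one place: 3-methoxyphenyl in place of 2-methylphenyl on a saturated chain carbon, two bonds along the chain from an oxygen next to a carbonyl group. Among the compounds with values here, no step between measured compounds bears on this change, so the only guidance is the closeness of compound 1 and compound 2. The expectation is a step in this assay of no more than the usual scatter, in either direction. Compound 3 is therefore expected to give about 250 nM, between 120 nM and 520 nM, which would mean an expected step of a 1.0-fold higher number from compound 2 to compound 3 (0.02 log units; within the scatter).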

Compound 3, half-maximal inhibitory concentration: 210 nM
Estimate against measurement, compound 3: 1.2-fold (0.08 log units) above; the measured number falls inside the stated range.
By their numbers in this assay, from the lowest: compounds 1, 3 and 2 (each within the scatter of the next).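

In this assay the change to 3-methoxyphenyl in place of 2-methylphenyl, on a saturated chain carbon, two bonds along the chain from an oxygen next to a carbonyl group, comes to a 1.1-fold lower number from compound 2 to compound 3 (0.06 log units; within the scatter) and so stays within the scatter even though the entering group brings one hydrogen-bond acceptor. Methoxy in place of trifluoromethyl on an aromatic carbon gives the first comparison that differs only in a single group on that ring, a 1.1-fold higher number from compound 1 to compound 3 (0.02 log units; within the scatter), and it also shows no difference that can be read. Nothing measured here offers an explanation for these results.

The compounds shown leave open whether an amine or a carboxylic acid on that ring would keep the number in the same range. They also leave open what a longer chain would do in place of the one carrying the ring.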